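The source may report more compounds than this note shows. Statements on the series, on what has been measured and on what is new or still open speak of the compounds shown alone.

Measured so far in a functional assay on HL-60 cells (Homo sapiens) for inhibition, read by CCK-8 assay, with a stated time of 48 h; on this read-out higher numbers stand for weaker inhibition and lower numbers for stronger inhibition:
- compound 1 `COc1ccc(S(=O)(=O)Oc2ccccc2/C=C(\C#N)C(=O)Nc2nnc(-c3cccs3)s2)cc1` gives 5230 nM
- compound 2 `COc1ccc(S(=O)(=O)Oc2ccccc2/C=C(\C#N)C(=O)Nc2nnc(Cc3ccc(F)cc3)s2)cc1` gives 4050 nM
- compound 3 `COc1ccc(S(=O)(=O)Oc2ccccc2/C=C(\C#N)C(=O)Nc2nnc(Cc3cccc(F)c3)s2)cc1` gives 3880 nM

Compound 3 stands within the scatter of both other compounds, with a 1.0-fold lower number from compound 2 to compound 3 (0.02 log units; within the scatter) and a 1.3-fold lower number from compound 1 to compound 3 (0.13 log units; within the scatter) as its two steps. Compound 4 `COc1ccc(S(=O)(=O)Oc2ccccc2/C=C(\C#N)C(=O)Nc2nnc(Cc3ccc(C)cc3)s2)cc1` differs from it in one place, 4-methylphenyl in place of 3-fluorophenyl on a saturated chain carbon bound to an aromatic carbon with 4-methylphenyl in place of 3-fluorophenyl on a saturated chain carbon bound to an aromatic carbon. The nearest measured change at this place is a 1.0-fold lower number from compound 2 to compound 3 (0.02 log units; within the scatter) and it exchanges 4-fluorophenyl for 3-fluorophenyl. The step of a 1.3-fold lower number from compound 1 to compound 2 (0.11 log units; within the scatter) replaces thiophen-2-yl with 4-fluorobenzyl and also stays small. Among the measured compounds shown here, no measured step brings in 4-methylphenyl, so this exchange itself is untested. For the measured compounds named here, all the measured steps lie within the scatter, and no step beyond it is expected in this assay here. The estimated step is a 1.0-fold higher number from compound 3 to compound 4 (0.01 log units; within the scatter) and it would leave the number essentially in place. Compound 4 is estimated at 4000 nM with an expected range of 2200 nM to 7000 nM in this measurement.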

Compound 4, half-maximal inhibitory concentration: 4080 nM
For compound 4 the middle estimate is 1.0-fold (0.01 log units) below the measured one; the measured number falls inside the stated range.
By their numbers in this assay, from the lowest: compounds 3, 2, 4 and 1 (each within the scatter of the next).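

In this assay, compound 4 puts a group without fluorine on the saturated chain carbon bound to an aromatic carbon, and exchanging 3-fluorophenyl for 4-methylphenyl gives a 1.1-fold higher number from compound 3 to compound 4 (0.02 log units; within the scatter). Methyl in place of fluoro on an aromatic carbon, a change of that single group, gives a 1.0-fold higher number from compound 2 to compound 4 (0.00 log units; within the scatter), so at this place the number holds with either fluoro or methyl. Putting 4-methylbenzyl in place of thiophen-2-yl gives a 1.3-fold lower number from compound 1 to compound 4 (0.11 log units; within the scatter), a step that also stays within the scatter, as those to the two fluorobenzyl groups do.

Nothing given here explains why these steps stay so small. All the groups shown at this place carry an aromatic ring, so it remains open whether an amine, a carboxylic acid or a longer chain there would move the number beyond the scatter.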